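Propyl to amino: a first step in a small series

The source may report more compounds than this note shows. Statements on the series, on what has been measured and on what is new or still open speak of the compounds shown alone.

In a functional assay on NCI-H460 cells (Homo sapiens) for positive allosteric modulation, read by MTT assay, with stated times of 2 h and 72 h, tested at 10 uM (a higher number here means a weaker inhibitor, a lower number a stronger inhibitor), compound 1 (`COc1ccc(C(=O)Nc2ccccc2-c2nnn(-c3ccc(OC)cc3)n2)cc1`) gives 149 nM as its half-maximal inhibitory concentration, and compound 2 (`CCCc1ccc(C(=O)Nc2ccccc2-c2nnn(-c3cccc(OC)c3)n2)cc1`) gives 121 nM on the same read-out. These two values lie within the usual scatter of each other, so compound 2 stands level with compound 1. Among the compounds with values here, their structures differ in more than one place, and the series offers no measured single-change step.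

Compound 3 (`COc1cccc(-n2nnc(-c3ccccc3NC(=O)c3ccc(N)cc3)n2)c1`) keeps the rest of compound 2 and carries amino in place of propyl on an aromatic carbon, para to a large group (amino in place of propyl on an aromatic carbon). The same difference reads 4-propylphenyl to 4-aminophenyl. Within the data shown here, with no measured step to size this change, the expectation in this assay is a moderate move toward a higher number, meaning a weaker inhibitor, though a result within the scatter cannot be excluded. The expected change is a 2.1-fold higher number from compound 2 to compound 3 (0.32 log units; beyond the scatter) on this estimate alone. For compound 3 the estimated value is 250 nM with an expected range from 80 nM to 800 nM at this stage.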

Compound 3, half-maximal inhibitory concentration: 211 nM
Beside the measured number, compound 3's estimate is 1.2-fold (0.07 log units) above it; the range from low to high includes it.
By their numbers in this assay, from the lowest: compounds 2, 1 and 3 (each within the scatter of the next).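

Working notes on the series: the only single-change step so far, amino in place of propyl on an aromatic carbon, para to a large group, reads a 1.7-fold higher number from compound 2 to compound 3 (0.24 log units; within the scatter) in this assay. On this read-out, the two compounds therefore stand level, although 4-propylphenyl and 4-aminophenyl differ in size and the amino brings a hydrogen-bond donor and a hydrogen-bond acceptor that propyl lacks. No information on what lies behind this result is available for this position.

Within the data shown here, the single step covers only these two groups at this one place, so it sets no trend, and compound 1 differs from the others in more than one place and adds no second step. Open questions are how a longer chain, a carboxylic acid or a dimethylamino group at the same place would read in this assay, and whether amino in place of propyl would read the same way with the methoxy group of the shared core placed as in compound 1.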